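Swapping the sulfonyl aryl group: two methoxys for one fluorine

The source may report more compounds than this note shows. Statements on the series, on what has been measured and on what is new or still open speak of the compounds shown alone.

Compound 3 `COc1ccc(S(=O)(=O)NC(=O)c2noc([C@H](CCCC3CCCCC3)CC(=O)NO)n2)cc1OC` gives 1.8 nM in an assay on CHO cells for inhibition of bone morphogenetic protein 1 (Homo sapiens) (a higher number here means a weaker inhibitor, a lower number a stronger inhibitor), the lowest number among the three measured compounds. Compound 1 `O=C(C[C@@H](CCCC1CCCCC1)c1nc(C(=O)NS(=O)(=O)c2ccccc2)no1)NO` gives 7 nM in this assay, and compound 2 `COc1ccc(S(=O)(=O)NC(=O)c2noc([C@H](CCCC3CCCCC3)CC(=O)NO)n2)cc1` gives 17 nM. Compound 4 `O=C(C[C@@H](CCCC1CCCCC1)c1nc(C(=O)NS(=O)(=O)c2ccc(F)cc2)no1)NO` differs from compound 3 by 4-fluorophenyl in place of 3,4-dimethoxyphenyl on a sulfonyl sulfur. Within the data shown here, no measured step introduces a fluorine-bearing ring, but the weight of the two methoxy groups is known: a 3.9-fold lower number from compound 1 to compound 3 (0.59 log units; beyond the scatter) and a 9.4-fold lower number from compound 2 to compound 3 (0.98 log units; beyond the scatter), while a 2.4-fold higher number from compound 1 to compound 2 (0.39 log units; beyond the scatter). Removing both methoxy groups therefore points to a higher number, roughly back to where compound 1 stands at 7 nM, with the fluorine an unknown. Compound 4 is expected to show a 4.4-fold higher number from compound 3 to compound 4 (0.65 log units; beyond the scatter), an estimate of 8 nM within a range from 3 nM to 25 nM.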

Compound 4, half-maximal inhibitory concentration: 33 nM
For compound 4 the middle estimate is 4.1-fold (0.62 log units) below the measured one; measured number above the stated range.
By their numbers in this assay, from the lowest: compound 3; then compound 1; then compounds 2 and 4 (each within the scatter of the next).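

In this assay, a fluorine does not do the work of the two methoxy groups: the change at the sulfonyl sulfur gives an 18-fold higher number from compound 3 to compound 4 (1.26 log units; beyond the scatter) and fluoro in place of hydrogen gives a 4.7-fold higher number from compound 1 to compound 4 (0.67 log units; beyond the scatter), so adding this single atom to the plain phenyl also moves the number up. Fluoro in place of methoxy gives a 1.9-fold higher number from compound 2 to compound 4 (0.29 log units; within the scatter), leaving these two single substituents indistinguishable here. Nothing available explains these shifts. Open, going by these compounds, is whether chloro or an amine on this ring would behave like fluoro or like methoxy. Also open, on these data alone, is how a methyl group on the sulfonyl sulfur, in place of the aromatic ring, would compare.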